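Triazole aryl variation on the shared core in MCF7 cytotoxicity

A few compounds are considered here, and "the series" means these few. Any claim that something is new, unique, unknown or untested is made for them only; others in the source may bear on it.

Measured compounds:
compound 1 `C=C1C(=O)[C@]23C[C@@]1(O)CC[C@H]2c1ccc(O)c(C)c1[C@@H]3Cn1cc(-c2ccccc2)nn1` — 1740 nM
compound 2 `Cc1ccc(S(=O)(=O)Oc2ccc3c(c2C)[C@H](Cn2cc(-c4ccccn4)nn2)[C@@]24CC(=O)[C@@](C)(CC[C@@H]32)C4)cc1` — > 20000 nM
compound 3 `C=C1C[C@]23C[C@@]1(O)CC[C@H]2c1ccc(O)c(C)c1[C@@H]3Cn1cc(-c2ccc(Br)cc2)nn1` — > 20000 nM

Among the measured compounds shown here, in a functional assay on MCF7 cells (Homo sapiens) for cytotoxicity, read by MTT assay, with a stated time of 4 days (a higher number here means a weaker inhibitor, a lower number a stronger inhibitor), compound 1 gives 1740 nM, the only numerical value in the set. For compound 2 this assay reports only a limit, > 20000 nM. For compound 3 likewise only a limit is reported, > 20000 nM. Two of the three values therefore sit at the limit of > 20000 nM in this assay, at which 2 of the 3 values shown sit, and compound 1 alone stands as a measured number; no pair of these compounds differs in a single place, so no step size is established.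

Compound 4 `C=C1C(=O)[C@]23C[C@@]1(O)CC[C@H]2c1ccc(O)c(C)c1[C@@H]3Cn1cc(-c2ccc(C(F)(F)F)cc2)nn1` is not yet measured. It differs from compound 1 by trifluoromethyl in place of hydrogen on an aromatic carbon. For the measured compounds named here, with no measured step of this kind, the expectation is a modest move, if any, probably toward weaker inhibition, yet within a range that includes no change beyond the scatter. Compound 4 is estimated at 3000 nM in this assay, from 1000 nM to 15000 nM, a step of a 1.7-fold higher number from compound 1 to compound 4 (0.24 log units; within the scatter).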

Compound 4, half-maximal inhibitory concentration: 1840 nM
Compound 4: middle estimate off by 1.6-fold (0.21 log units), on the high side; measured number inside the range.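

In this assay, among the compounds shown here, the swap from phenyl to 4-(trifluoromethyl)phenyl gives a 1.1-fold higher number from compound 1 to compound 4 (0.02 log units; within the scatter), the first step that can be read. At this place on the aromatic ring, on the core of compound 1, a group of four heavy atoms is therefore accommodated with the two values inside the scatter of each other, though this rests on a single pair. Compound 2 and compound 3 add no step, as each differs from compound 1 in more than one place and each value is only a limit of the assay: the limit of > 20000 nM in this assay, at which 2 of the 4 values shown sit.

On these data alone, whether an amine or a carboxylic acid at the same place would give a step beyond the scatter remains open. Also open, as far as these compounds go, is whether trifluoromethyl gives the same result on a different core.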